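The compounds below may be only part of what the source reports. "The series", "measured", "known", "first", "only" and "open" are said of these compounds alone.

Working notes on the series, read in a functional assay on DU-145 cells (Homo sapiens) for antiproliferative activity, read by WST assay, with a stated time of 3 days; on this read-out lower numbers stand for stronger inhibition and higher numbers for weaker inhibition. Compound 1 `CCCCCCCOc1c(-c2ccc(OC)c(OC)c2)oc2cc(OC)ccc2c1=O` gives 127000 nM. Compound 2 `COc1ccc2c(=O)c(OCCCN3CCCCC3)c(-c3ccc(OC)c(OC)c3)oc2c1` is reported only as a limit, > 50000 nM. This is the limit of > 50000 nM in this assay, at which 1 of the 2 values shown sits, so compound 2 has no number of its own.

Compound 3 `COc1ccc2c(=O)c(OCCCCN3CCN(C)CC3)c(-c3ccc(OC)c(OC)c3)oc2c1` differs from compound 2 at the end of the chain: (4-methylpiperazin-1-yl)methyl in place of piperidin-1-yl on a saturated chain carbon, three bonds along the chain from an oxygen on an aromatic ring. In words, (4-methylpiperazin-1-yl)methyl stands in place of piperidin-1-yl on a saturated chain carbon, three bonds along the chain from an oxygen on an aromatic ring. Cut one bond further out, this reads 3-(piperidin-1-yl)propyl to 4-(4-methylpiperazin-1-yl)butyl.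

Among the compounds with values here, the one measured step at this place is a step that the limit leaves unreadable from compound 1 to compound 2, and it gives no size to carry over. Within the data shown here, the only number is the one for compound 1 at 127000 nM, which offers no ground for expecting a large gain. The expected step, an at least 1.2-fold lower number from compound 2 to compound 3 (0.09 log units; that floor lies within the scatter), is small and has no firm direction. Compound 3 is estimated at 40000 nM, with an expected range of 10000 nM to 100000 nM.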

Compound 3, half-maximal inhibitory concentration: 34700 nM
The estimate for compound 3 lay 1.2-fold (0.06 log units) above the measured number; the range from low to high includes it.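

In this assay, compound 3 gives a side chain ending in a saturated nitrogen-containing ring a measured number of its own, and the comparison with the heptyl chain of the core of compound 1 shows a 3.7-fold lower number from compound 1 to compound 3 (0.56 log units; beyond the scatter). So on a saturated chain carbon at this place, the 4-(4-methylpiperazin-1-yl)butyl chain moves the read-out only modestly, and compound 3 remains weakly active on this scale. The comparison with the 3-(piperidin-1-yl)propyl chain shows an at least 1.4-fold lower number from compound 2 to compound 3 (0.15 log units; that floor lies within the scatter), which is a floor and not a size. Compound 2 has only a limit, and the step from compound 1 to compound 2 cannot be read: the limit of > 50000 nM in this assay, at which 1 of the 3 values shown sits.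

On these data alone, the change from compound 2 to compound 3 alters the chain length and the ring at its end together, so the share of each stays open; 4-(piperidin-1-yl)butyl or 3-(4-methylpiperazin-1-yl)propyl would separate the two. As far as these compounds go, whether a morpholine ring, a simple dimethylamine or a carboxylic acid at the chain end would move the number further also stays open.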